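The compounds below may be only part of what the source reports. "The series", "measured", "known", "first", "only" and "open" are said of these compounds alone.

Compound 1 `CCCCC(C)C[C@]1(CC)O[C@H]1[C@]1(CC)C=CC(=O)O1`: 31500 nM
Compound 2 `CCCCC(C)C/C(=C/[C@@]1(CC)OC(=O)C[C@@H]1O)CC`: 31200 nM
Compound 3 `CCCCC(C)CC(O)(/C=C(/CC)[C@@H](O)CC(=O)OC)CC`: 15500 nM

These three compounds were tested in a functional assay on HeLa cells (Homo sapiens) for cytotoxicity, read by MTT assay, with a stated time of 72 h; on this read-out higher numbers stand for weaker inhibition and lower numbers for stronger inhibition. Compound 1, at 31500 nM, sits level with compound 2 within the usual scatter of repeated measurements. The number for compound 3 is lower than that of compound 1, and this gap lies beyond the scatter.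

Compound 4 `CCCCC(CC)C[C@]1(CC)O[C@H]1[C@]1(CC)C=CC(=O)O1` has not yet been measured. It differs from compound 1 as follows: methyl in place of hydrogen on a saturated chain carbon, three bonds along the chain from a saturated ring carbon. In words, a methyl replaces a hydrogen on a saturated chain carbon, three bonds along the chain from a saturated ring carbon, so 1-methylpentyl becomes 1-ethylpentyl.

Among the measured compounds shown here, no two measured compounds differ in only one place, so the data offer no direct guide to the size of this step. With so small a change, no shift beyond the scatter is expected, and compound 1 at 31500 nM serves as the anchor. The expected step is a 1.1-fold lower number from compound 1 to compound 4 (0.02 log units; within the scatter). For compound 4 the estimated value is 30000 nM, with an expected range from 15000 nM to 60000 nM.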

Compound 4, half-maximal inhibitory concentration: > 50000 nM
Compound 4: no number, only a limit; the forecaster's own chance of this, stated with the estimate: 8%; at least 1.6-fold (0.22 log units) between middle value and limit.
By their numbers in this assay, from the lowest: compounds 3, 2 and 1 (each within the scatter of the next, the first and the last beyond it). At a limit, above all of these: compound 4.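

Among the compounds shown here, the change from 1-methylpentyl to 1-ethylpentyl is the first change in a single place in this set, and in this assay it gives an at least 1.5-fold higher number from compound 1 to compound 4 (0.20 log units; that floor lies within the scatter). Compound 4 reads > 50000 nM, which is a limit of the assay and not a number, so only the floor of the step is known, not its true size. The added methyl, on a saturated chain carbon three bonds along the chain from a saturated ring carbon, brought no stronger inhibition, and the reading ends at a limit: the limit of > 50000 nM in this assay, at which 1 of the 4 values shown sits.

On these data alone, it remains open whether a longer chain at this place, or an amine or a hydroxyl on the same carbon, would move the number in either direction. As far as these compounds go, it is also open whether the same 1-ethylpentyl group would give a similar result on the cores of compound 2 and compound 3.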